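Dichlorobenzyl isomers across two cores: working notes

A few compounds are considered here, and "the series" means these few. Any claim that something is new, unique, unknown or untested is made for them only; others in the source may bear on it.

All numbers below come from a functional assay on MCF7 cells (Homo sapiens) for inhibition, read by MTT assay, with a stated time of 72 h; a lower number here means a stronger inhibitor, a higher number a weaker inhibitor.

compound 1, `C=CCc1ccc(O)c(-c2ccc(OCc3ccc(Cl)c(Cl)c3)c(CC=C)c2)c1`: compound 1 gives 15300 nM
compound 2, `C=CCc1ccc(O)c(-c2ccc(OCc3c(Cl)cccc3Cl)c(CC=C)c2)c1`: compound 2 gives 11500 nM
compound 3, `C=CCc1ccc(OCc2ccc(Cl)c(Cl)c2)c(-c2ccc(O)c(CC=C)c2)c1`: compound 3 gives 17500 nM

Compounds 1 and 2 share one core; compound 3 carries the alternative core, with the phenol and the ether exchanged between the two rings. The difference between the core of compound 1 and the core of compound 3 is not broken down here. Compound 3 and compound 1 are within the scatter of each other, as are compound 3 and compound 2, so no ordering among the three is claimed.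

The change from compound 1 to compound 2 is 2,6-dichlorophenyl in place of 3,4-dichlorophenyl on a saturated chain carbon bound to an oxygen on an aromatic ring. It gave a 1.3-fold lower number from compound 1 to compound 2 (0.12 log units; within the scatter).

Compound 4, `C=CCc1ccc(OCc2c(Cl)cccc2Cl)c(-c2ccc(O)c(CC=C)c2)c1`, is not yet measured in this assay. It arises from compound 3 by 2,6-dichlorophenyl in place of 3,4-dichlorophenyl on a saturated chain carbon bound to an oxygen on an aromatic ring, the same change as between compound 1 and compound 2, at the same place. Among the compounds with values here, only one example of this change is known, so the expectation rests on that single step. The step from compound 3 to compound 4 is expected to be about a 1.3-fold lower number from compound 3 to compound 4 (0.10 log units; within the scatter) because of a 1.3-fold lower number from compound 1 to compound 2 (0.12 log units; within the scatter), i.e. within the scatter. For compound 4 the expected value is 14000 nM, with a likely range from 7000 nM to 28000 nM.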

Compound 4, half-maximal inhibitory concentration: 19400 nM
Compound 4: the middle estimate sits 1.4-fold (0.14 log units) below what was measured; measured number inside the range.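

On the alternative core, 2,6-dichlorobenzyl in place of 3,4-dichlorobenzyl gave a 1.1-fold higher number from compound 3 to compound 4 (0.04 log units; within the scatter) in this assay. Set beside the earlier step, the change shows no difference between the two cores: the same change on two cores in this assay, a 1.3-fold lower number (0.12 log units; within the scatter) from compound 1 to compound 2 and a 1.1-fold higher number (0.04 log units; within the scatter) from compound 3 to compound 4, 1.5-fold (0.17 log units) apart, within the scatter of two such steps. This shows that the change can be carried from one core to the other without a detectable shift in its outcome, but with both steps within the scatter it does not show that the change has a real effect on either core, and two cores say nothing about a third.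

The compounds shown leave open whether the benzyl group matters at all here, since each compound carries a dichlorophenyl group and the pattern of chlorines is the only thing varied on it. An amine or a carboxylic acid on that ring, or a longer chain in place of the allyl groups, would show whether anything in this series can move the number beyond the scatter.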